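Ethyl to methoxy on the shared core

This account rests on a few compounds, and the source may have more. Where it says the series, first, only, none or still open, it means among the compounds named here.

Values in a functional assay on A549 cells (Homo sapiens) for inhibition, read by MTT assay, with a stated time of 48 h; a lower number here means a stronger inhibitor, a higher number a weaker inhibitor:
- compound 1 `O=C(Nc1cccc(Cl)c1)Nc1ccc(-c2cc(=O)c3ccccc3o2)c(Cl)c1`: 14000 nM
- compound 2 `CCc1ccc2oc(-c3ccc(NC(=O)Nc4cccc(Cl)c4)cc3Cl)cc(=O)c2c1`: > 50000 nM (a limit)

Compound 2 gives no number, only the limit > 50000 nM. This is the limit of > 50000 nM in this assay, at which 1 of the 2 values shown sits.

The next compound is compound 3 `COc1ccc2oc(-c3ccc(NC(=O)Nc4cccc(Cl)c4)cc3Cl)cc(=O)c2c1`, with methoxy in place of ethyl on an aromatic carbon. Among the measured compounds shown here, one measured step bears on this carbon: an at least 3.5-fold higher number from compound 1 to compound 2 (0.55 log units; beyond the scatter), with ethyl in place of hydrogen. That step lies beyond the scatter, and its true size is open because it ends at a limit. Methoxy has no measured precedent in this series, so the expectation rests on this single step. Compound 1, with hydrogen at this carbon, gives 14000 nM, so a modest move to a lower number in this assay is expected. A second limit remains quite possible. The expected step is an at least 1.6-fold lower number from compound 2 to compound 3 (0.22 log units; that floor lies within the scatter). For compound 3 the estimate is 30000 nM, with an expected range of 12000 nM to 60000 nM.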

Compound 3, half-maximal inhibitory concentration: 11000 nM
For compound 3 the middle estimate is 2.7-fold (0.44 log units) above the measured one; measured number outside the range, below it.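

At this aromatic carbon the read-out in this assay turns on which group is present, not on size as counted: ethyl and methoxy hold the same count of heavy atoms, yet the change from ethyl to methoxy brings an at least 4.5-fold lower number from compound 2 to compound 3 (0.65 log units; beyond the scatter). Measured against hydrogen at the same carbon, methoxy brings a 1.3-fold lower number from compound 1 to compound 3 (0.10 log units; within the scatter), so this carbon accepts at least one substituent without a step that can be told from the scatter, and the poor result of compound 2 belongs to ethyl and not to substitution as such. The value for compound 2 is only a limit, so the step from ethyl to methoxy has a floor and no fixed size: the limit of > 50000 nM in this assay, at which 1 of the 3 values shown sits.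

The compounds shown leave open whether a hydroxyl group, an amine or a longer chain such as ethoxy at this carbon would follow methoxy or ethyl. With only hydrogen, ethyl and methoxy compared here, no rule for this carbon can be drawn, and no group shown gives a number lower than hydrogen by more than the scatter.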